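Thiazolyl Amide in Place of Dimethylanilide: Toxicity Outlook

The compounds below may be only part of what the source reports. "The series", "measured", "known", "first", "only" and "open" are said of these compounds alone.

Compound 2 `COc1ccc2nc(C)cc(OCC(=O)Nc3c(C)cccc3C)c2c1` was run in a toxicity assay on HepG2 cells (Homo sapiens) for inhibition, read by CellTiter-Glo, with a stated time of 48 h; a higher number here means a weaker inhibitor, a lower number a stronger inhibitor. Compound 2 returned only a limit there, > 100000 nM. That places compound 2 at the limit of > 100000 nM in this assay, at which 2 of the 3 values shown sit. Compound 1 `Cc1cc(C)cc(NC(=O)COc2cc(C)nc3ccc(OCc4ccccc4)cc23)c1` likewise returned only a limit, > 100000 nM. Compound 3 `COc1ccc2nc(C)cc(OCC(=O)Nc3ccc(Cl)c(C(F)(F)F)c3)c2c1` gave a measured number in this assay, 79400 nM. Compound 4 `COc1ccc2nc(C)cc(OCC(=O)Nc3nc(C)c(C)s3)c2c1` has not yet been tested. The change from compound 2 to compound 4 is 4,5-dimethyl-1,3-thiazol-2-yl in place of 2,6-dimethylphenyl on an amide-type nitrogen. Among the compounds with values here, no measured pair in this set isolates such a change, so the data give no direction for it, and a step no larger than the scatter is expected. Compound 4 is expected to give about 100000 nM, between 40000 nM and 300000 nM. The expected step of a number no higher from compound 2 to compound 4 (the limit leaves the size open) is within the scatter, most likely again as a limit.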

Compound 4, half-maximal inhibitory concentration: > 100000 nM
Compound 4 ended at the assay's limit; the forecaster's own chance of this, stated with the estimate: 70%; the middle value sits exactly at the limit.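

Within the data shown here, compound 2 and compound 4 both return only limits in this assay, so no step between them can be read: the limit of > 100000 nM in this assay, at which 3 of the 4 values shown sit. The compounds shown leave open whether 4,5-dimethyl-1,3-thiazol-2-yl in place of 2,6-dimethylphenyl changes the read-out at all.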